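Notes on a fused-core series: aryl for cycloalkyl

This account rests on a few compounds, and the source may have more. Where it says the series, first, only, none or still open, it means among the compounds named here.

compound 1 `CC[C@@H]1C(=O)N(C)c2cnc(-n3ccnc3-c3ccccc3)nc2N1C1CCCC1`: 0%
compound 2 `CCC1C(=O)N(C)c2cnc(-n3ccnc3-c3ccc(F)cc3)nc2N1C1CCC(F)(F)C1`: 15%

In an ADME assay on microsomes from liver (Mus musculus) for metabolic stability, with a stated time of 30 min, tested at 1 uM (a higher number here means that more of the compound is left, a lower number that less of the compound is left), compound 1 gives 0%, while compound 2 gives 15%. Compound 2 therefore stands highest of the two numbers, its gap to compound 1 lying beyond the usual scatter. Compound 3 `CCC1C(=O)N(C)c2cnc(-n3ccnc3-c3ccc(F)cc3)nc2N1c1ccc(F)cc1` has not been measured; it differs from compound 2 in one place: 4-fluorophenyl in place of 3,3-difluorocyclopentyl on a nitrogen on an aromatic ring in a ring. Going by the values given here, no measured pair covers this kind of change, so nothing here sets its size. The step of a number 7 percentage points higher from compound 2 to compound 3 (within the scatter) is expected to be small and upward, possibly within the scatter. Compound 3 is estimated at 22%, with a range from 5% to 45%.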

Compound 3, percent of the compound remaining in the liver assay: 41%
Compound 3: middle estimate off by 19 percentage points, on the low side; the measured number falls inside the stated range.
By their numbers in the liver assay, from the lowest: compound 1; then compound 2; then compound 3.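

On the nitrogen of the ring that bears the ethyl group, 4-fluorophenyl in place of 3,3-difluorocyclopentyl gives in the liver assay a number 26 percentage points higher from compound 2 to compound 3 (beyond the scatter) and so shows that an aromatic ring is tolerated at this position, with more compound left. In a physicochemical assay for lipophilicity (on this read-out lower numbers stand for lower lipophilicity and higher numbers for higher lipophilicity), compound 2 gives 3.1 and compound 3 gives 3.4 and these two stand within the scatter of each other. Nothing at hand accounts for the step in the liver assay.

This single step changes ring type and fluorine count together, and the two cannot be separated. Open, on these data alone, is whether a pyridyl ring or a morpholine on this nitrogen would hold the number in the liver assay.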